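The compounds below may be only part of what the source reports. "The series", "measured", "known", "first", "only" and "open" are said of these compounds alone.

Of the compounds shown here, two have been measured in an assay on cells for agonist activity at ecdysone receptor (Bombyx mori), read by a luciferase reporter, with a stated time of 24 h; a lower number here means that less compound is needed, a higher number that more compound is needed for the effect. Compound 1 `CCc1ccc(C(=O)NN(C(=O)c2ccccc2Cl)C(C)(C)C)cc1` gives 5.75 nM. Going by the values given here, compound 2 `COc1ccc(C(=O)NN(C(=O)c2ccccc2Cl)C(C)(C)C)cc1` gives 51.3 nM, the highest of the two numbers; its only neighbour is compound 1, separated by the step of an 8.9-fold higher number from compound 1 to compound 2 (0.95 log units; beyond the scatter). Compound 3 `Cc1ccc(C)c(C(=O)NN(C(=O)c2ccccc2Cl)C(C)(C)C)c1` is still to be measured in this assay. It differs from compound 2 by 2,5-dimethylphenyl in place of 4-methoxyphenyl on a carbonyl carbon; the carbonyl carbon in question has an amide-type nitrogen as its other neighbour. Among the compounds with values here, the only measured step that bears on this change is an 8.9-fold higher number from compound 1 to compound 2 (0.95 log units; beyond the scatter), which goes the other way: the group that enters in compound 3 carries no acceptor, as in compound 1, so a return toward the number of compound 1 is expected, with the caveat that two methyl groups on the ring are not an ethyl group. Compound 3 is expected at 15 nM, within 4 nM to 60 nM. For compound 3 this means an expected step of a 3.4-fold lower number from compound 2 to compound 3 (0.53 log units; beyond the scatter).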

Compound 3, half-maximal effective concentration: 1620 nM
Estimate against measurement, compound 3: 110-fold (2.03 log units) below; measured number above the stated range.
By their numbers in this assay, from the lowest: compound 1; then compound 2; then compound 3.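

In this assay the aryl group on the carbonyl carbon turns out to govern the number over a much wider span than the first step suggested: a 32-fold higher number from compound 2 to compound 3 (1.50 log units; beyond the scatter) and a 280-fold higher number from compound 1 to compound 3 (2.45 log units; beyond the scatter) are both large steps. The absence of a hydrogen-bond acceptor does not by itself set the number at this position, since 4-ethylphenyl and 2,5-dimethylphenyl both lack one, yet compound 1 and compound 3 lie furthest apart of the three, with the 4-methoxyphenyl of compound 2 between them. No measurement at hand accounts for this rise.

The compounds shown leave open whether the rise follows from one of the two methyl groups or from both together, as no ring with a single methyl group is among them. Going by these compounds, how a ring bearing an amine or a carboxylic acid would stand also remains open.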